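A silicon-bearing group on compound 1

The source may hold more compounds than are shown below. What is called first, only, known or untested is meant among the compounds shown, and "the series" means these compounds.

Compound 1 `COc1cc(C2=C(c3cc(C)c(OC)c(C)c3)C(O)CC2=O)cc(OC)c1OC` gives no exact number on the scale used here. In an ADME assay on PA-1 cells (Homo sapiens) for cytotoxicity, read by MTT assay, with a stated time of 72 h (a lower number here means a stronger inhibitor, a higher number a weaker inhibitor), compound 1 gives > 100 ug/mL as a limit of the assay, not a number. Compound 2 `COc1ccc(C2=C(c3cc(OC)c(OC)c(OC)c3)C(=O)C(O)C2)cc1F` likewise gives > 100 ug/mL as a limit. Going by the values given here, the evidence so far is therefore the limit of > 100 ug/mL in this assay, at which 2 of the 2 values shown sit, and nothing more, and no measured step is available for comparison. Compound 3 `COc1cc(C2=C(c3cc(C)c(OC)c(C)c3)C(O[SiH2]C(C)(C)C)CC2=O)cc(OC)c1OC` is compound 1 with one change, (a group of 5 heavy atoms (4 carbon, 1 silicon; no ring) in place of a hydrogen atom, on an oxygen on a saturated carbon), while the rest of the structure stays the same. Among the compounds with values here, with no measured step to guide it, this expectation is tentative, and compound 3 may well remain at the limit in this assay as well. The estimated change, an at least 1.6-fold lower number from compound 1 to compound 3 (0.22 log units; that floor lies within the scatter), is a modest one toward stronger inhibition. For compound 3 the expected value is 60 ug/mL, with an estimated range from 15 ug/mL to 100 ug/mL in this measurement.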

Compound 3, half-maximal inhibitory concentration: 32 ug/mL
Compound 3: middle estimate off by 1.9-fold (0.27 log units), on the high side, within the range that was stated.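

In this assay, placing a group of 5 heavy atoms (4 carbon, 1 silicon; no ring) in place of a hydrogen atom, on an oxygen on a saturated carbon, gives an at least 3.1-fold lower number from compound 1 to compound 3 (0.49 log units; beyond the scatter). Going by these compounds alone, this is the first sign that this oxygen is a place where a single change can bring a compound off the limit of the assay. Compound 3 gives 32 ug/mL, a true number. The other compounds shown stay at that limit, so compound 3 stands alone in this set: the limit of > 100 ug/mL in this assay, at which 2 of the 3 values shown sit.

What the compounds shown leave open is whether the silicon itself matters, or whether an all-carbon group or a small methyl group on the same oxygen would do the same. An amine-bearing chain at this place, or the same silicon-bearing group on compound 2, also remains an open case.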